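This account rests on a few compounds, and the source may have more. Where it says the series, first, only, none or still open, it means among the compounds named here.

Measured compounds:
Compound 1, `Cc1ccc(Cl)cc1Nc1nc(C(F)(F)F)ccc1CNC(=O)C(C)c1ccc(NS(C)(=O)=O)c(F)c1`, gives 14 nM in a functional assay on CHO-K1 cells for antagonist activity at transient receptor potential cation channel subfamily V member 1 (Homo sapiens), read by FLIPR; on this read-out higher numbers stand for weaker inhibition and lower numbers for stronger inhibition.
Compound 2, `CC(C(=O)NCc1ccc(C(F)(F)F)nc1N1CCCC1)c1ccc(NS(C)(=O)=O)c(F)c1`, gives 0.6 nM in this assay.

Compound 2 stands at the lowest of the two numbers. Among the measured compounds shown here, its nearest neighbour is compound 1, and the single measured step, a 23-fold lower number from compound 1 to compound 2 (1.37 log units; beyond the scatter), is what separates them. That step concerns the group on the aromatic carbon next to the ring nitrogen and shows how much the number can move when that group is exchanged.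

Compound 3, `CC(C(=O)NCc1ccc(C(F)(F)F)nc1N1CCCCCCC1)c1ccc(NS(C)(=O)=O)c(F)c1`, has not been measured. It differs from compound 2 in one place: a group of 8 heavy atoms (7 carbon, 1 nitrogen; one eight-membered non-aromatic ring with 1 hetero atom) in place of a group of 5 heavy atoms (4 carbon, 1 nitrogen; one five-membered non-aromatic ring with 1 hetero atom), on an aromatic carbon. For the measured compounds named here, no measured step addresses this exchange; the one step recorded swaps an amino-linked aromatic group for the pyrrolidin-1-yl group, not one ring for another of different size. With nothing in the data that speaks to the eight-membered ring, the expected step in this assay is small, at most a modest rise, and it may well stay within the scatter.

For compound 3 the expected step is a 2.5-fold higher number from compound 2 to compound 3 (0.40 log units; beyond the scatter). Compound 3 is therefore estimated at 1.5 nM, within a range from 0.4 nM to 6 nM.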

Compound 3, inhibition constant: 0.7 nM
Beside the measured number, compound 3's estimate is 2.1-fold (0.33 log units) above it, within the range that was stated.
By their numbers in this assay, from the lowest: compounds 2 and 3 (each within the scatter of the next); then compound 1.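

In this assay, exchanging pyrrolidin-1-yl for the eight-membered non-aromatic ring on the aromatic carbon next to the ring nitrogen gives a 1.2-fold higher number from compound 2 to compound 3 (0.07 log units; within the scatter) so this read-out does not tell the two rings apart. The position thus accepts a non-aromatic ring of 8 heavy atoms as well as one of 5 heavy atoms, and the larger ring also gives a 20-fold lower number from compound 1 to compound 3 (1.30 log units; beyond the scatter) which shows that the large distance from the amino-linked aromatic group first seen as a 23-fold lower number from compound 1 to compound 2 (1.37 log units; beyond the scatter) is not tied to pyrrolidin-1-yl alone. Nothing in the material at hand accounts for why these two rings read alike in this assay.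

What the compounds shown leave open is whether the tolerance holds for a ring carrying a second hetero atom, such as morpholin-4-yl, or for an open-chain amine such as diethylamino, at this same position. They also leave open whether a piperidin-1-yl group, which falls in size between the two rings, would read like them, so the two rings compared here cannot be taken to describe every ring size.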